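The source may report more compounds than this note shows. Statements on the series, on what has been measured and on what is new or still open speak of the compounds shown alone.

Working notes on the series.

Compound 1 `CC(CC(=O)O)N1Cc2ccc(NC(=O)CCCC3CCNCC3)cc2C1=O` is the reference for the first core; in a functional assay on a cell-free system (Platelet, plasma, Homo sapiens) for inhibition (on this read-out higher numbers stand for weaker inhibition and lower numbers for stronger inhibition), compound 1 gives 5400 nM. Compound 2 `O=C(O)CN1Cc2ccc(NC(=O)CCCC3CCNCC3)cc2C1=O` carries the same core and differs only in the change (carboxymethyl in place of 1-(carboxymethyl)ethyl on an amide-type nitrogen in a ring). In this assay compound 2 gives 66000 nM, so the step is a 12-fold higher number from compound 1 to compound 2 (1.09 log units; beyond the scatter).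

Compound 3 `CC(CC(=O)O)N1Cc2ccc(NC(=O)c3ccc(N4CCNCC4)cc3)cc2C1=O` has a different core; the difference between the two cores is not broken down here. In this assay compound 3 gives 3740 nM. Its number and that of compound 1 lie within the usual scatter of each other, so no order between them is drawn; compound 2 stands beyond the scatter from compound 3.

Compound 4 `O=C(O)CN1Cc2ccc(NC(=O)c3ccc(N4CCNCC4)cc3)cc2C1=O` is not yet measured. Within the data shown here, it differs from compound 3 by carboxymethyl in place of 1-(carboxymethyl)ethyl on an amide-type nitrogen in a ring, which is the same change as the one from compound 1 to compound 2, made at the same place on the five-membered ring of the shared core. Because a 12-fold higher number from compound 1 to compound 2 (1.09 log units; beyond the scatter) is large and well beyond the scatter, the expectation is that compound 4 loses a comparable amount against compound 3; the step expected is a 12-fold higher number from compound 3 to compound 4 (1.08 log units; beyond the scatter), with the second core as the only point of uncertainty, since the change has been seen only once. In this assay compound 4 is estimated at 45000 nM, expected to fall between 15000 nM and 150000 nM.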

Compound 4, half-maximal inhibitory concentration: 3300 nM
Compound 4: middle estimate off by 14-fold (1.13 log units), on the high side; the whole stated range lies above it.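

On the core of compound 3, carboxymethyl in place of 1-(carboxymethyl)ethyl on the amide-type nitrogen in the ring gives a 1.1-fold lower number from compound 3 to compound 4 (0.05 log units; within the scatter) in this assay, so the large step seen on the core of compound 1, a 12-fold higher number from compound 1 to compound 2 (1.09 log units; beyond the scatter), does not carry over to this second core. The size of this change therefore depends on the core it sits on, and a step read on one core in this series cannot be transferred to the other: the same change on two cores in this assay, a 12-fold higher number (1.09 log units; beyond the scatter) from compound 1 to compound 2 and a 1.1-fold lower number (0.05 log units; within the scatter) from compound 3 to compound 4, 14-fold (1.14 log units) apart, beyond the scatter of two such steps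

This rests on one pair of compounds per core, so it shows that the two cores differ in their response but not which part of the cores is responsible, nor which of the two steps would be the more usual on a further core.

The compounds shown leave open how a longer chain carrying the carboxylic acid on the same nitrogen would read on each core, and whether an ester in place of the carboxylic acid would follow the same split. Also open, on these data alone, is how this change would behave on a core that keeps the benzamide but carries a different amine in place of the piperazine.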